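This account rests on a few compounds, and the source may have more. Where it says the series, first, only, none or still open, it means among the compounds named here.

Measured in a functional assay on MCF7 cells (Homo sapiens) for antiproliferative activity, read by MTT assay, with a stated time of 72 h; on this read-out lower numbers stand for stronger inhibition and higher numbers for weaker inhibition:
- compound 1 `COc1cccc(-c2ncnn2-c2cc(OC)c(OC)c(OC)c2)c1`: > 10000 nM
- compound 2 `COc1cc(-n2ncnc2-c2cccc(F)c2)cc(OC)c1OC`: > 10000 nM

Both values are limits, not numbers: compound 1 and compound 2 stand at the limit of > 10000 nM in this assay, at which 2 of the 2 values shown sit. Going by the values given here, the only measured step, a step that the two limits leave unreadable from compound 1 to compound 2, gives no size to carry forward.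

Compound 3 `COc1cc(-n2ncnc2-c2ccc(SC)cc2)cc(OC)c1OC` carries 4-(methylsulfanyl)phenyl in place of 3-fluorophenyl on an aromatic carbon.

Since compound 2 gives > 10000 nM, a limit, any readable value could lie only toward stronger inhibition. Among the compounds with values here, no measured step supports a size, and another limit remains possible. The expected change is an at least 5.0-fold lower number from compound 2 to compound 3 (0.69 log units; beyond the scatter). For compound 3 the estimate is 2000 nM, with an expected range of 50 nM to 10000 nM.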

Compound 3, half-maximal inhibitory concentration: 390 nM
Compound 3: the middle estimate sits 5.1-fold (0.71 log units) above what was measured; low and high end bracket the measured number.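

In this assay, 4-(methylsulfanyl)phenyl is the only group shown at this position that gives a readable value, so the position is not closed to activity: against 3-fluorophenyl the change is an at least 25-fold lower number from compound 2 to compound 3 (1.40 log units; beyond the scatter). Against 3-methoxyphenyl it is an at least 25-fold lower number from compound 1 to compound 3 (1.40 log units; beyond the scatter). Both sizes are minimums, because each starting value is a limit: the limit of > 10000 nM in this assay, at which 2 of the 3 values shown sit.

Whether the sulfur atom is needed stays open, as no other group with a substituent in the same place on the phenyl ring is shown. From the compounds shown here alone, it is also open whether an amine, a carboxylic acid or a longer chain on the sulfur in place of the methyl would keep a readable value.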